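Ring Size and Chain Length Against Cytotoxicity in Rat Cells

This account rests on a few compounds, and the source may have more. Where it says the series, first, only, none or still open, it means among the compounds named here.

Compound 1 `c1ccc(C2CC3(N4CCCC4)CCN(CCN4CCCC4)C2C(c2ccccc2)C3)cc1`: 58200 nM
Compound 2 `c1ccc(C2CC3(N4CCCC4)CCN(CCCN4CCCCC4)C2C(c2ccccc2)C3)cc1`: 28700 nM
Compound 3 `c1ccc(C2CC3(N4CCCCC4)CCN(CCN4CCCC4)C2C(c2ccccc2)C3)cc1`: 156000 nM

These three compounds were tested in an ADME assay on L6 cells (Rattus norvegicus) for cytotoxicity; a lower number here means a stronger inhibitor, a higher number a weaker inhibitor. They share one core and differ in two places. Compound 2 differs from compound 1 by (piperidin-1-yl)methyl in place of pyrrolidin-1-yl on a saturated chain carbon, two bonds along the chain from an amine nitrogen in a ring; that change gives a 2.0-fold lower number from compound 1 to compound 2 (0.31 log units; beyond the scatter). Compound 3 differs from compound 1 by piperidin-1-yl in place of pyrrolidin-1-yl on a saturated ring carbon; that change gives a 2.7-fold higher number from compound 1 to compound 3 (0.43 log units; beyond the scatter). With both of its steps beyond the scatter, compound 3 is the weakest inhibitor of the three in this assay, and compound 2 the strongest.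

Compound 4 `c1ccc(C2CC3(N4CCCCC4)CCN(CCCN4CCCCC4)C2C(c2ccccc2)C3)cc1` has not been measured yet. It differs from compound 3 by (piperidin-1-yl)methyl in place of pyrrolidin-1-yl on a saturated chain carbon, two bonds along the chain from an amine nitrogen in a ring. This is the same change that was made from compound 1 to compound 2, at the same place, so it occurs twice among these compounds; the two pairs differ only in how their cores differ, which is the change from compound 1 to compound 3 given above. Among the compounds with values here, because a 2.0-fold lower number from compound 1 to compound 2 (0.31 log units; beyond the scatter) was seen once, the expectation is for a step of about the same size from compound 3, namely a 2.0-fold lower number from compound 3 to compound 4 (0.30 log units; within the scatter), though with only one earlier example the size is uncertain. Compound 4 is therefore estimated to give 78000 nM in this assay. The expected range for compound 4 runs from 40000 nM to 160000 nM.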

Compound 4, half-maximal inhibitory concentration: 138000 nM
Compound 4: the middle estimate sits 1.8-fold (0.25 log units) below what was measured; the range from low to high includes it.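

In this assay, putting (piperidin-1-yl)methyl in place of pyrrolidin-1-yl on the chain gives a 1.1-fold lower number from compound 3 to compound 4 (0.05 log units; within the scatter), so the step falls within the scatter on this core although it lay beyond the scatter on the other, yet that contrast is too small to count as a real difference between the cores: the same change on two cores in this assay, a 2.0-fold lower number (0.31 log units; beyond the scatter) from compound 1 to compound 2 and a 1.1-fold lower number (0.05 log units; within the scatter) from compound 3 to compound 4, 1.8-fold (0.25 log units) apart, within the scatter of two such steps. The change of ring on the saturated ring carbon, piperidin-1-yl in place of pyrrolidin-1-yl, gives a 4.8-fold higher number from compound 2 to compound 4 (0.68 log units; beyond the scatter), in the same direction as its earlier step and again not measurably different from it: the same change on two cores in this assay, a 2.7-fold higher number (0.43 log units; beyond the scatter) from compound 1 to compound 3 and a 4.8-fold higher number (0.68 log units; beyond the scatter) from compound 2 to compound 4, 1.8-fold (0.25 log units) apart, within the scatter of two such steps. Each change therefore carries over between these two cores without a detectable shift, but each comparison rests on a single pair of steps, so this does not show that the changes would carry over to other cores, and it does not explain why the numbers move.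

The chain step alters ring size and chain length together, so a 2-(piperidin-1-yl)ethyl or a 3-(pyrrolidin-1-yl)propyl group would be needed to separate the two contributions. As far as these compounds go, it also remains open how a morpholin-4-yl ring or a longer chain would behave in this assay.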